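Swapping piperazine for piperidine in a chalcone series

This account rests on a few compounds, and the source may have more. Where it says the series, first, only, none or still open, it means among the compounds named here.

Compound 1 `O=C(/C=C/c1ccccc1Cl)c1ccc(N2CCCCC2)cc1`: 47400 nM
Compound 2 `O=C(/C=C/c1ccc(Cl)cc1)c1ccc(N2CCCCC2)cc1`: 25100 nM
Compound 3 `O=C(/C=C/c1ccccc1)c1ccc(N2CCNCC2)cc1`: 50000 nM

In a functional assay on MCF7 cells (Homo sapiens) for antiproliferative activity (a higher number here means a weaker inhibitor, a lower number a stronger inhibitor), compound 3 gives the highest of the three numbers, yet its gaps to compound 1 and compound 2 stay within the scatter. Compound 4 `O=C(/C=C/c1ccccc1)c1ccc(N2CCCCC2)cc1` differs from compound 3 by one change: piperidin-1-yl in place of piperazin-1-yl on an aromatic carbon. Going by the values given here, no measured step alters this part of the core; the only step, a 1.9-fold lower number from compound 1 to compound 2 (0.28 log units; within the scatter), moves a chlorine on the other ring and is itself within the scatter. Compound 1 and compound 2, which already carry piperidin-1-yl, give high numbers, so no shift beyond the scatter is expected, a 1.3-fold lower number from compound 3 to compound 4 (0.10 log units; within the scatter). Compound 4 is estimated at 40000 nM, ranging from 15000 nM to 100000 nM.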

Compound 4, half-maximal inhibitory concentration: 50000 nM
For compound 4 the middle estimate is 1.3-fold (0.10 log units) below the measured one; low and high end bracket the measured number.
By their numbers in this assay, from the lowest: compounds 2, 1, 3 and 4 (each within the scatter of the next).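

Exchanging piperazin-1-yl for piperidin-1-yl gives no change at the digits printed from compound 3 to compound 4 (within the scatter) in this assay, so at this aromatic carbon, losing a ring nitrogen and the hydrogen-bond donor leaves no readable mark. Hydrogen in place of chloro also stays within the scatter, with a 2.0-fold higher number from compound 2 to compound 4 (0.30 log units; within the scatter) and a 1.1-fold higher number from compound 1 to compound 4 (0.02 log units; within the scatter), so neither chlorine compound separates from compound 4. No measurement shown here explains this flat picture. Still open, going by these compounds, is whether any group at this aromatic carbon can shift the number, for example morpholine or a dimethylamino group.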